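Added methoxy groups and melanocortin receptor 4 binding

The source may report more compounds than this note shows. Statements on the series, on what has been measured and on what is new or still open speak of the compounds shown alone.

Measured in an assay on HEK293 cells for displacement of a labelled ligand from Melanocortin receptor 4 (Homo sapiens); on this read-out higher numbers stand for weaker inhibition and lower numbers for stronger inhibition:
- compound 1, `CCC(C)[C@H](N)c1cc(C(F)(F)F)ccc1N1CCN(C(=O)CCc2ccc(OC)cc2Cl)CC1`: 57 nM
- compound 2, `CCC(C)[C@H](N)c1cc(C(F)(F)F)ccc1N1CCN(C(=O)CCc2ccc(OC)c(OC)c2Cl)CC1`: 2500 nM
- compound 3, `COc1ccc(OC)c(CCC(=O)N2CCN(c3ccc(C(F)(F)F)cc3[C@@H](N)CC(C)C)CC2)c1`: 2500 nM

Compound 2 differs from compound 1 by methoxy in place of hydrogen on an aromatic carbon. This single change gave a 44-fold higher number from compound 1 to compound 2 (1.64 log units; beyond the scatter), a large loss of binding in this assay. Compound 3 carries a different substitution pattern on its side-chain ring; the difference between compound 1 and compound 3 is not broken down here, and the two values simply show that compound 3 sits at the same weak level as compound 2.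

Compound 4, `COc1cc(OC)c(OC)cc1CCC(=O)N1CCN(c2ccc(C(F)(F)F)cc2[C@@H](N)CC(C)C)CC1`, is not yet measured. It differs from compound 3 by methoxy in place of hydrogen on an aromatic carbon. This is the same kind of change as that from compound 1 to compound 2, but not the same: in compound 2 the entering group sits ortho to a chloro group, ortho to a methoxy group and meta to a large group, whereas in compound 4 it sits ortho to a methoxy group, meta to a methoxy group and para to a large group. Within the data shown here, only one measured step of this kind exists, so the expectation rests on it loosely: compound 3 is already weak at 2500 nM, and adding a further methoxy is expected to leave binding weak or weaken it somewhat further, so for compound 4 a step of a 2.0-fold higher number from compound 3 to compound 4 (0.30 log units; within the scatter) is expected. For compound 4 the estimate in this assay is 5000 nM, with a likely range from 1500 nM to 20000 nM.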

Compound 4, inhibition constant: 6100 nM
Compound 4: the middle estimate sits 1.2-fold (0.09 log units) below what was measured; the range from low to high includes it.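

Across the two cores, in this assay, methoxy in place of hydrogen on an aromatic carbon moves the number the same way, and the new pair shows a 2.4-fold higher number from compound 3 to compound 4 (0.39 log units; beyond the scatter), but the size of the step does not carry over: the same change on two cores in this assay, a 44-fold higher number (1.64 log units; beyond the scatter) from compound 1 to compound 2 and a 2.4-fold higher number (0.39 log units; beyond the scatter) from compound 3 to compound 4, 18-fold (1.25 log units) apart, beyond the scatter of two such steps

On these two pairs, then, the earlier step gave the direction of the change on the second core but not its size, so a step read on one core in this series cannot be transferred as a number to another. Two pairs establish no rule, and they do not show what sets the gap: the entering methoxy stands at a different place in each pair and the surrounding ring substituents also differ, so the core and the place of substitution cannot be separated here.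

As far as these compounds go, it remains open whether methoxy entering at one fixed place on the ring would give steps of matching size on both cores, which would need the same ring substitution carried on each. Also open, from the compounds shown here alone, is how a hydroxy group or a fluorine atom at the place taken by the new methoxy would compare with the 2,4,5-trimethoxyphenyl compound.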